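Shortening the dialkylamino chains of compound 1

A few compounds are considered here, and "the series" means these few. Any claim that something is new, unique, unknown or untested is made for them only; others in the source may bear on it.

Compound 1 `CCCN(CCC)c1nc(C)nc2c(-c3ccc(OC)nc3C)c(C)nn12` gives 5.7 nM in an assay on cell membranes for displacement of a labelled ligand from corticotropin-releasing factor receptor 1 (Rattus norvegicus); on this read-out lower numbers stand for stronger inhibition and higher numbers for weaker inhibition; compound 2 `CCCC(C)Nc1nc(C)nc2c(-c3ccc(OC)nc3C)c(C)nn12` gives 3.5 nM in this assay.

Compound 1 holds the higher of the two numbers in this assay, with compound 2 nearest at a 1.6-fold lower number from compound 1 to compound 2 (0.21 log units; within the scatter). Compound 3 `CCN(CC)c1nc(C)nc2c(-c3ccc(OC)nc3C)c(C)nn12` differs from compound 1 by diethylamino in place of dipropylamino on an aromatic carbon. Among the measured compounds shown here, the only measured step at this aromatic carbon is a 1.6-fold lower number from compound 1 to compound 2 (0.21 log units; within the scatter), which lies within the scatter, but it brings in a different group, so the data say nothing directly about shorter chains here. A modest weakening is expected, a 2.1-fold higher number from compound 1 to compound 3 (0.32 log units; beyond the scatter). Compound 3 is therefore estimated at 12 nM, within 4 nM to 40 nM.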

Compound 3, half-maximal inhibitory concentration: 12 nM
Compound 3: the middle estimate sits on the measured number at the digits printed, within the range that was stated.
By their numbers in this assay, from the lowest: compounds 2 and 1 (each within the scatter of the next); then compound 3.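

In this assay, among the compounds shown here, replacing dipropylamino with diethylamino on this aromatic carbon gives a modest weakening (a 2.1-fold higher number from compound 1 to compound 3 (0.32 log units; beyond the scatter)), the first step at this position beyond the scatter. Diethylamino also falls behind (1-methylbutyl)amino (a 3.4-fold higher number from compound 2 to compound 3 (0.54 log units; beyond the scatter)), so the position responds modestly to the choice of amino group. Nothing given here accounts for either step.

As far as these compounds go, whether dimethylamino or dibutylamino would move the number further remains open. So does the effect of a ring amine such as morpholine at this carbon.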